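Swapping carboxy for methoxy on the weakest compound

The source may report more compounds than this note shows. Statements on the series, on what has been measured and on what is new or still open speak of the compounds shown alone.

- compound 1 `O=C(/C(=C\c1ccc(OCc2ccccc2)cc1)SCc1ccc(Cl)cc1)c1ccc(Cl)cc1` gives 1000 nM
- compound 2 `O=C(O)c1ccc(C(=O)/C(=C\c2ccc(O)c([N+](=O)[O-])c2)SCc2ccc(Br)cc2)cc1` gives 50000 nM
- compound 3 `COc1cc(/C=C(/SCc2ccc(Br)cc2)C(=O)c2ccc(C(=O)O)cc2)ccc1F` gives 1000 nM

In a functional assay on DU-145 cells (Homo sapiens) for inhibition, read by trypan blue exclusion, with a stated time of 96 h (on this read-out lower numbers stand for stronger inhibition of growth and higher numbers for weaker inhibition of growth), compound 2 stands highest of the three at 50000 nM and so inhibits growth most weakly, with compound 1 and compound 3 both well below it.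

Compound 4 `COc1ccc(C(=O)/C(=C\c2ccc(O)c([N+](=O)[O-])c2)SCc2ccc(Br)cc2)cc1` alters compound 2 in one place methoxy in place of carboxy on an aromatic carbon so that 4-carboxyphenyl becomes 4-methoxyphenyl. For the measured compounds named here, no measured step makes this change. The only one available is a 50-fold lower number from compound 2 to compound 3 (1.70 log units; beyond the scatter) and it concerns a different group, which compound 4 leaves as it is in compound 2. Going by the values given here, that large step shows only that numbers in this family can move far. Compound 3 keeps the carboxy yet gives 1000 nM while compound 1 lacks it and gives 1000 nM but differs in several other places. The evidence is thin, so a lower number in this assay is expected only tentatively, and a smaller drop than the measured step. The expected change is an 8.3-fold lower number from compound 2 to compound 4 (0.92 log units; beyond the scatter) and it remains uncertain. For compound 4 the estimate is 6000 nM with an expected range from 800 nM to 50000 nM.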

Compound 4, concentration for 50% growth inhibition: 10000 nM
The estimate for compound 4 lay 1.7-fold (0.22 log units) below the measured number; measured number inside the range.
By their numbers in this assay, from the lowest: compounds 1 and 3 (each within the scatter of the next); then compound 4; then compound 2.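

For the compounds shown here, this is the first direct reading of the group on this aromatic carbon, para to a large group, and with everything else held fixed, methoxy in place of carboxy gives a 5.0-fold lower number from compound 2 to compound 4 (0.70 log units; beyond the scatter) in this assay on growth inhibition. For this pair, then, the carboxy is not needed for inhibition of growth, and the 4-methoxyphenyl compound inhibits growth more strongly than the 4-carboxyphenyl one by a modest step beyond the usual scatter. The data at hand offer no measurement that explains why the number falls with this swap.

The compounds shown leave open whether the same swap would lower the number on compound 3, which carries 4-fluoro-3-methoxyphenyl instead of 4-hydroxy-3-nitrophenyl. They also leave open how an amine or an ethoxy group on this same aromatic carbon would compare with methoxy.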